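Swapping a phenyl for a thiophene ring in a weak inhibitor

The source may report more compounds than this note shows. Statements on the series, on what has been measured and on what is new or still open speak of the compounds shown alone.

Of the compounds shown here, three have been measured in a functional assay on HeLa cells (Homo sapiens) for inhibition, with a stated time of 72 h; a lower number here means that less compound is needed, a higher number that more compound is needed for the effect. Compound 1 `COc1cc(CNCc2ccncc2)ccc1OCc1cccc(F)c1` gives 4800 nM, compound 3 `CCOc1cc(CNCc2ccncc2)ccc1OCc1ccc(Cl)cc1` gives 2500 nM, and compound 2 `COc1cc(CNCc2ccccc2)ccc1OCc1ccc(Cl)nc1` gives 90000 nM. Compound 2 therefore stands with the highest number of the three, needing far more material than either of the others, and the gap to both is beyond the usual scatter. Among the compounds with values here, compounds 1 and 3 carry a pyridin-4-yl group where compound 2 carries a phenyl, but they also differ elsewhere, so no single step between measured compounds can be read off.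

Compound 4 `COc1cc(CNCc2cccs2)ccc1OCc1ccc(Cl)nc1` has not yet been measured. It is made from compound 2 by thiophen-2-yl in place of phenyl on a saturated chain carbon bound to an amine nitrogen. Within the data shown here, nothing among the measured compounds shows what this particular exchange does in this assay, so the expectation rests on the observation that compound 2 is the weakest point of the set and that a heteroaromatic ring at this place accompanies lower numbers in compounds 1 and 3.

For compound 4 a modest improvement is expected, with a step of a 1.8-fold lower number from compound 2 to compound 4 (0.26 log units; within the scatter) that may well not exceed the scatter. The estimate for compound 4 is 50000 nM, with a range from 15000 nM to 150000 nM.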

Compound 4, half-maximal effective concentration: 96000 nM
Compound 4: middle estimate off by 1.9-fold (0.28 log units), on the low side; measured number inside the range.
By their numbers in this assay, from the lowest: compounds 3 and 1 (each within the scatter of the next); then compounds 2 and 4 (each within the scatter of the next).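

In this assay, thiophen-2-yl in place of phenyl on a saturated chain carbon bound to an amine nitrogen gives a 1.1-fold higher number from compound 2 to compound 4 (0.03 log units; within the scatter), so this pair cannot be told apart. At this place in this compound pair, a five-membered aromatic ring containing sulfur therefore reads the same as a six-membered aromatic ring of carbon only, and merely having a hetero atom in the ring does not by itself separate the two numbers. No independent measurement is available to say why the two rings read alike.

Within the data shown here, compounds 1 and 3 differ from compound 2 and compound 4 in more than one place, so no steps to them can be read, and it remains open whether a pyridin-4-yl group at this place, on the core of compound 2, would give a different number from phenyl or thiophen-2-yl. Also open, on these data alone, is whether a saturated ring such as cyclohexyl, or a phenyl ring carrying a carboxylic acid, would move the number at this place.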